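Cyano in Place of Nitro: From Compound 2 to Compound 4

The compounds below may be only part of what the source reports. "The series", "measured", "known", "first", "only" and "open" are said of these compounds alone.

Measured so far in an assay on isolated protein for inhibition of Aromatase (Homo sapiens), read by fluorescence, using NADPH, with a stated time of 30 min, tested at 50 uM; a lower number here means less inhibition, a higher number more inhibition at the concentration tested (going by the name of the read-out):
compound 1 `Clc1ccc(-c2cc3ccccc3[nH]2)cc1Cl` gives 22.7%;
compound 2 `O=[N+]([O-])c1ccc2[nH]c(-c3cccnc3)cc2c1` gives 27.9%;
compound 3 `Cc1ccccc1-c1cc2cc([N+](=O)[O-])ccc2[nH]1` gives 71.5%.

Compound 2 stands second highest of these three numbers. Its nearest neighbour is compound 1, whose number lies within the scatter of compound 2, so no order between them can be claimed. Compound 3 lies beyond the scatter above compound 2.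

Compound 4 `N#Cc1ccc2[nH]c(-c3cccnc3)cc2c1` differs from compound 2 in one place: cyano in place of nitro on an aromatic carbon. Among the compounds with values here, no measured pair shows this change, so its size is unknown. Both groups lack donors and both carry acceptors, and the change is expected to leave the number roughly where it is in this assay, no step beyond the scatter in either direction, as a number 1.9 percentage points lower from compound 2 to compound 4 (within the scatter).

Compound 4 is expected to give about 26%, from 10% to 45%.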

Compound 4, a percentage reported as inhibition, at one concentration (the size of the read-out at that concentration, not a potency): 93.7%
For compound 4 the middle estimate is 67.7 percentage points below the measured one; the whole stated range lies below it.
By their numbers in this assay, from the lowest: compounds 1 and 2 (each within the scatter of the next); then compound 3; then compound 4.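

In this assay, within the data shown here, cyano in place of nitro on this aromatic carbon brings a number 65.8 percentage points higher from compound 2 to compound 4 (beyond the scatter) and so gives the first step that can be read in this set. It shows that the number is highly sensitive to the group held at this position, at least on the core of compound 2. No evidence at hand accounts for the step.

As far as these compounds go, whether the same change would act alike with the ring that compound 3 carries remains open. So does how an amine or a carboxylic acid would read at this position.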